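Rearranging a methylated seven-membered ring

The compounds below may be only part of what the source reports. "The series", "measured", "known", "first", "only" and "open" are said of these compounds alone.

compound 1 `C[C@@H]1CN(S(=O)(=O)c2ccc(NC(=O)NCc3cccnc3)cc2)C[C@H](C)O1`: 15 nM
compound 2 `C[C@@H]1COC[C@@H](C)N1S(=O)(=O)c1ccc(NC(=O)NCc2cccnc2)cc1`: 745 nM
compound 3 `CC1CNCCN(S(=O)(=O)c2ccc(NC(=O)NCc3cccnc3)cc2)C1`: 99 nM

All three values come from a functional assay on A2780 cells (Homo sapiens) for antiproliferative activity, read by sulforhodamine B assay, with a stated time of 72 h; a lower number here means a stronger inhibitor, a higher number a weaker inhibitor. Compound 3 holds the middle place of the three, as a 6.6-fold higher number from compound 1 to compound 3 (0.82 log units; beyond the scatter) and a 7.5-fold lower number from compound 2 to compound 3 (0.88 log units; beyond the scatter) show. Compound 4 `CC1CCN(S(=O)(=O)c2ccc(NC(=O)NCc3cccnc3)cc2)CCN1` contains the same atoms as compound 3, joined differently: a group of 8 heavy atoms (6 carbon, 2 nitrogen; one seven-membered non-aromatic ring with 2 hetero atoms) in place of a group of 8 heavy atoms (6 carbon, 2 nitrogen; one seven-membered non-aromatic ring with 2 hetero atoms), on a sulfonyl sulfur. The ring type stays the same, so those two steps, which both change the ring, say little here. Going by the values given here, the closest precedent is a 50-fold higher number from compound 1 to compound 2 (1.70 log units; beyond the scatter), where 3,5-dimethylmorpholin-4-yl replaces 2,6-dimethylmorpholin-4-yl. That change also keeps the ring size and shows that a rearrangement alone can matter greatly in this series. However, it is a single case in a different ring, so it sets no firm direction for compound 4. A clear step is therefore not expected, though the range must stay wide. The expected step is a 1.2-fold higher number from compound 3 to compound 4 (0.08 log units; within the scatter). For compound 4 the estimate is 120 nM, with an expected range of 40 nM to 400 nM.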

Compound 4, half-maximal inhibitory concentration: 109 nM
Estimate against measurement, compound 4: 1.1-fold (0.04 log units) above; the range from low to high includes it.
By their numbers in this assay, from the lowest: compound 1; then compounds 3 and 4 (each within the scatter of the next); then compound 2.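

In this assay, rearranging the atoms of the seven-membered ring gives a 1.1-fold higher number from compound 3 to compound 4 (0.04 log units; within the scatter), so this change leaves the two compounds within the scatter, whereas the rearrangement of the dimethylmorpholine ring gave a 50-fold higher number from compound 1 to compound 2 (1.70 log units; beyond the scatter). The seven-membered ring of compound 4 also lies between the two dimethylmorpholines, with a 6.8-fold lower number from compound 2 to compound 4 (0.83 log units; beyond the scatter) and a 7.3-fold higher number from compound 1 to compound 4 (0.86 log units; beyond the scatter), so a rearrangement need not have a large effect in this series. Nothing given here explains why one rearrangement matters so much more than the other. Going by these compounds alone, with only one pair of seven-membered rings, it remains unknown whether other arrangements of the same atoms would also stay within the scatter. On these data alone, it is also open whether an ethyl group in place of the methyl group on this ring would change the number.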